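The source may hold more compounds than are shown below. What is called first, only, known or untested is meant among the compounds shown, and "the series" means these compounds.

Going by the values given here, in a functional assay on HCT-15 cells (Homo sapiens) for inhibition (a higher number here means a weaker inhibitor of growth, a lower number a stronger inhibitor of growth), compound 2 `NC(=O)c1cc(I)ccc1NC(=O)COc1ccccc1` gives 253 nM, the lower of the two numbers so far, while compound 1 `NC(=O)c1cc(Cl)ccc1NC(=O)COc1ccccc1` gives 1570 nM. Compound 3 `COc1ccc(NC(=O)COc2ccccc2)c(C(N)=O)c1` has methoxy in place of iodo on an aromatic carbon. Among the compounds with values here, only one measured step bears on this change, the modest 6.2-fold lower number from compound 1 to compound 2 (0.79 log units; beyond the scatter), with iodo in place of chloro. Within the data shown here, no methoxy compound has been measured yet, so that step gives only a rough guide, and leaving iodo is expected to raise the number by a similar amount. The expected step is a 5.5-fold higher number from compound 2 to compound 3 (0.74 log units; beyond the scatter). For compound 3 the estimated value is 1400 nM, with an expected range of 450 nM to 4500 nM.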

Compound 3, concentration for 50% growth inhibition: 432 nM
The estimate for compound 3 lay 3.2-fold (0.51 log units) above the measured number; measured number outside the range, below it.
By their numbers in this assay, from the lowest: compounds 2 and 3 (each within the scatter of the next); then compound 1.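

Iodo and methoxy on this aromatic carbon, para to a large group, cannot be told apart in this assay, with a 1.7-fold higher number from compound 2 to compound 3 (0.23 log units; within the scatter), so a group that is not a halogen can match iodo here. Methoxy, however, is clearly separated from chloro, with a 3.6-fold lower number from compound 1 to compound 3 (0.56 log units; beyond the scatter), so the earlier gap between the halogens is not simply a split between iodo and everything else. Nothing measured here explains these differences.

As far as these compounds go, whether an amine, a carboxylic acid or a longer chain such as ethoxy would keep this level at the same position remains open.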